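A few compounds are considered here, and "the series" means these few. Any claim that something is new, unique, unknown or untested is made for them only; others in the source may bear on it.

Measured compounds:
compound 1 `CN(C)C(=O)c1cc2cnc(Nc3ccc(NC(=O)C4(C(=O)Nc5ccccc5F)CC4)cc3)nc2n1C1CCCC1`, 89.6%
compound 2 `CN(C)C(=O)c1cc2cnc(Nc3ccc(NC(=O)C4(C(=O)Nc5cccc(O)c5)CC4)cc3)nc2n1C1CCCC1`, 78.5%
compound 3 `CN(C)C(=O)c1cc2cnc(Nc3ccc(NC(=O)C4(C(=O)Nc5ccc(F)cc5)CC4)cc3F)nc2n1C1CCCC1`, 82.6%

In a functional assay on NCI-H1299 cells (Homo sapiens) for inhibition, read by CCK-8 assay, with a stated time of 72 h, tested at 10 uM (a higher number here means more inhibition of growth at the concentration tested, a lower number less inhibition of growth), compound 2 gives the lowest of the three numbers; compound 3 lies within the scatter of it, compound 1 stands beyond the scatter above it. Compound 4 `CN(C)C(=O)c1cc2cnc(Nc3ccc(NC(=O)C4(C(=O)Nc5ccc(Cl)c(C(F)(F)F)c5)CC4)cc3)nc2n1C1CCCC1` is not yet measured. The change from compound 2: 4-chloro-3-(trifluoromethyl)phenyl in place of 3-hydroxyphenyl on an amide-type nitrogen. Going by the values given here, one measured step bears on this: a number 11.1 percentage points lower from compound 1 to compound 2 (beyond the scatter), in which 3-hydroxyphenyl entered and the number fell. Compound 4 removes the 3-hydroxyphenyl again, bringing in a fluorine- and chlorine-bearing phenyl. Given a number 11.1 percentage points lower from compound 1 to compound 2 (beyond the scatter), an upward step of similar size is expected for compound 4 a number 7.5 percentage points higher from compound 2 to compound 4 (within the scatter). Compound 3, carrying 4-fluorophenyl, gives 82.6%, which supports the same direction. Compound 4 is estimated at 86%, range 75% to 95%.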

Compound 4, percent growth inhibition at one concentration: 90.4%
Compound 4: middle estimate off by 4.4 percentage points, on the low side; the range from low to high includes it.
By their numbers in this assay, from the lowest: compounds 2, 3, 1 and 4 (each within the scatter of the next, the first and the last beyond it).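

In this assay, 4-chloro-3-(trifluoromethyl)phenyl in place of 3-hydroxyphenyl gives a number 11.9 percentage points higher from compound 2 to compound 4 (beyond the scatter) on the amide-type nitrogen, so the lower number of compound 2 does not extend to this halogen-bearing phenyl with no hydrogen-bond donor. The comparison with 2-fluorophenyl, a number 0.8 percentage points higher from compound 1 to compound 4 (within the scatter) in the same assay, leaves these two differently substituted phenyl groups unseparated. No available data account for either step.

Open, going by these compounds, is whether an aminomethyl group or a carboxylic acid on this phenyl ring keeps the number high. Also open, on these data alone, is whether compound 1 and compound 4 separate at lower concentrations.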